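Swapping the para substituent of a potent trimethoxyphenyl analog

This account rests on a few compounds, and the source may have more. Where it says the series, first, only, none or still open, it means among the compounds named here.

Among the measured compounds shown here, compound 2 `COc1cc(-c2ccnc3cc(-c4ccc(N(C)C)cc4)nn23)cc(OC)c1OC` is the only compound here with a numerical result: in a functional assay on MCF7 cells (Homo sapiens) for inhibition, read by CCK-8 assay, with a stated time of 48 h (a lower number here means a stronger inhibitor, a higher number a weaker inhibitor), compound 2 gives 44 nM. Compound 1 `COc1cc(-c2ccnc3cc(-c4cccc(C#N)c4)nn23)cc(OC)c1OC` is its partner, and in this assay compound 1 reaches only > 10000 nM, which is a limit of the assay rather than a number (the limit of > 10000 nM in this assay, at which 1 of the 2 values shown sits). For the measured compounds named here, the one measured step, an at least 220-fold lower number from compound 1 to compound 2 (2.35 log units; beyond the scatter), shows that changing the group on the pendant ring can move the result greatly.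

Compound 3 `COc1cc(-c2ccnc3cc(-c4ccc(C(C)(C)C)cc4)nn23)cc(OC)c1OC` keeps everything of compound 2 except that one group: tert-butyl in place of dimethylamino on an aromatic carbon. Going by the values given here, no measured step covers exactly this change, so the expectation rests only on the observation from compound 1 to compound 2 that the group on this ring matters. In this assay compound 3 is expected to give 400 nM, within 60 nM to 5000 nM, a weakening estimated as a 9.1-fold higher number from compound 2 to compound 3 (0.96 log units; beyond the scatter).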

Compound 3, half-maximal inhibitory concentration: > 10000 nM
Compound 3: only a limit was reported (the forecaster's own chance of this, stated with the estimate: 15%); middle value at least 25-fold (1.39 log units) from the limit.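

Compound 3 shows that keeping a group at the same place, para to a large group, is not enough: tert-butyl in place of dimethylamino gives an at least 220-fold higher number from compound 2 to compound 3 (2.35 log units; beyond the scatter). Among the compounds shown here, compound 1 differed from compound 2 in both the group and where it sat, so this is the first step that changes the group alone. Of the three pendant groups shown, only dimethylamino, which brings the one hydrogen-bond acceptor counted in this change, gives a numerical result in this assay. The step from compound 1 to compound 3 cannot be read, since both ends are limits: the limit of > 10000 nM in this assay, at which 2 of the 3 values shown sit.

Still open, from the compounds shown here alone, is whether this result needs dimethylamino itself, or whether a methoxy group, a plain amine or a diethylamino group at this place would also give a numerical result.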